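Swapping the sulfur-linked ring in a cytotoxicity series

A few compounds are considered here, and "the series" means these few. Any claim that something is new, unique, unknown or untested is made for them only; others in the source may bear on it.

Compound 2 `Cn1nnnc1SCC(=O)Nc1ccc(-c2nc(-c3ccccc3)c(-c3ccccc3)n2C)cc1` carries a 1-methyl-1H-tetrazol-5-yl group on a sulfur. Among the measured compounds shown here, in a functional assay on HT-29 cells (Homo sapiens) for cytotoxicity, read by MTT assay, with a stated time of 24 h (a higher number here means a weaker inhibitor, a lower number a stronger inhibitor), compound 2 gives 1.6 ug/mL, the lowest of the two numbers measured so far. Its nearest neighbour is compound 1 `Cn1c(-c2ccc(NC(=O)CSc3nc4ccccc4o3)cc2)nc(-c2ccccc2)c1-c1ccccc1`, which has a 1,3-benzoxazol-2-yl group on that sulfur and gives 11 ug/mL in this assay. For the measured compounds named here, the only step measured so far, a 6.9-fold lower number from compound 1 to compound 2 (0.84 log units; beyond the scatter), shows that exchanging the ring on this sulfur can move the number well beyond the scatter. Compound 3 `Cn1c(-c2ccc(NC(=O)CSC3=NCCS3)cc2)nc(-c2ccccc2)c1-c1ccccc1` makes a further exchange at the same place: a group of 5 heavy atoms (3 carbon, 1 nitrogen, 1 sulfur; one five-membered non-aromatic ring with 2 hetero atoms) in place of a group of 6 heavy atoms (2 carbon, 4 nitrogen; one five-membered aromatic ring with 4 hetero atoms), on a sulfur. Going by the values given here, no measured step covers this particular replacement, so the direction is uncertain; the one comparison available only shows that this position is sensitive, and compound 2 already stands at the low end. Compound 3 is therefore expected to give a somewhat higher number, estimated at 4 ug/mL with a range of 1.2 ug/mL to 14 ug/mL. That expectation corresponds to a 2.5-fold higher number from compound 2 to compound 3 (0.40 log units; beyond the scatter).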

Compound 3, half-maximal inhibitory concentration: 21 ug/mL
Beside the measured number, compound 3's estimate is 5.3-fold (0.72 log units) below it; the whole stated range lies below it.
By their numbers in this assay, from the lowest: compound 2; then compounds 1 and 3 (each within the scatter of the next).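

The exchange at this sulfur can do more than the first comparison showed: in this assay, replacing the 1-methyl-1H-tetrazol-5-yl group with the five-membered non-aromatic ring gives a 13-fold higher number from compound 2 to compound 3 (1.12 log units; beyond the scatter), a large step in the weaker direction. Replacing the 1,3-benzoxazol-2-yl group with that same non-aromatic ring gives a 1.9-fold higher number from compound 1 to compound 3 (0.28 log units; within the scatter), so these two groups cannot be told apart here, and among the three only the 1-methyl-1H-tetrazol-5-yl group stands clear of the others. Nothing available explains why this group stands apart.

It remains open whether the methyl on the tetrazole matters, since a plain 1H-tetrazol-5-yl group is not among the compounds shown. A 1,2,4-triazole ring or a simple ethyl chain on this sulfur would show how far the low number depends on the tetrazole ring itself.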